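Working notes: the step to compound 3

The source may hold more compounds than are shown below. What is called first, only, known or untested is meant among the compounds shown, and "the series" means these compounds.

In a functional assay on K562 cells (Homo sapiens) for cytotoxicity, read by sulforhodamine B assay (a lower number here means a stronger inhibitor of growth, a higher number a weaker inhibitor of growth), compound 1 `CC1=CC[C@@H]([C@@](C)(O)CCCC(C)(C)NC(=S)N/N=C\c2ccccc2)CC1` reads 130 nM and compound 2 `CC1=CC[C@@H]([C@@](C)(O)CCCC(C)(C)NC(=S)N/N=C\c2ccc(N(C)C)cc2)CC1` reads 80 nM so compound 2 stands level with compound 1 within the scatter. For the measured compounds named here, the only measured step of a 1.6-fold lower number from compound 1 to compound 2 (0.21 log units; within the scatter) is dimethylamino in place of hydrogen on an aromatic carbon. Compound 3 `CC1=CC[C@@H]([C@@](C)(O)CCCC(C)(C)NC(=S)N/N=C\c2cccc([N+](=O)[O-])c2)CC1` differs by 3-nitrophenyl in place of 4-(dimethylamino)phenyl on a carbon with a double bond to nitrogen with 3-nitrophenyl in place of 4-(dimethylamino)phenyl on a carbon with a double bond to nitrogen. Going by the values given here, no measured compound carries a nitro group, so this guide is weak. The expected step is a 1.5-fold higher number from compound 2 to compound 3 (0.18 log units; within the scatter) and nothing beyond the scatter is expected. Compound 3 is estimated at 120 nM (range 50 nM to 300 nM).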

Compound 3, concentration for 50% growth inhibition: 20 nM
For compound 3 the middle estimate is 6.0-fold (0.78 log units) above the measured one; the whole stated range lies above it.
By their numbers in this assay, from the lowest: compound 3; then compounds 2 and 1 (each within the scatter of the next).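

The aryl group on the carbon with a double bond to nitrogen can shift the number in this assay beyond the scatter, which the dimethylamino step did not show. Here 3-nitrophenyl in place of 4-(dimethylamino)phenyl gives a clear drop (a 4.0-fold lower number from compound 2 to compound 3 (0.60 log units; beyond the scatter)), and nitro in place of hydrogen on an aromatic carbon gives a similar one (a 6.5-fold lower number from compound 1 to compound 3 (0.81 log units; beyond the scatter)). No measurement on hand accounts for this drop.

On these data alone, whether the drop follows the nitro group itself or its place on the ring stays open. So does whether 4-nitrophenyl, or a nitrile or trifluoromethyl group on the same ring, reads like compound 3.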